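This account rests on a few compounds, and the source may have more. Where it says the series, first, only, none or still open, it means among the compounds named here.

Working notes on the series.

The shared core carries a trifluoromethoxy group and an imine; the compounds differ only in the chain on the aromatic nitrogen. Compound 1 `COC(=O)Cn1c(=N)sc2cc(OC(F)(F)F)ccc21` bears a methoxycarbonylmethyl chain, and in a functional assay on the whole organism with Rattus norvegicus as the target (on this read-out lower numbers stand for an effect already at smaller amounts and higher numbers for an effect only at larger amounts of compound), compound 1 gives only a limit of the assay, > 10 mg/kg, so the limit of > 10 mg/kg in this assay, at which 1 of the 3 values shown sits, applies. Compound 2 `N=c1sc2cc(OC(F)(F)F)ccc2n1CC(N)=O` carries the carbamoyl analogue and in this assay compound 2 gives 7 mg/kg. Compound 3 `CSCCn1c(=N)sc2cc(OC(F)(F)F)ccc21` carries a 2-(methylsulfanyl)ethyl chain and in this assay compound 3 gives 1 mg/kg, the lowest of the two numbers in hand.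

For the measured compounds named here, the steps that bear on the chain are an at least 10-fold lower number from compound 1 to compound 3 (1.00 log units; beyond the scatter) and a 7.0-fold lower number from compound 2 to compound 3 (0.85 log units; beyond the scatter); the comparison of compound 1 with compound 2 gives an at least 1.4-fold lower number from compound 1 to compound 2 (0.15 log units; that floor lies within the scatter).

Compound 4 `CN(C)CCCn1c(=N)sc2cc(OC(F)(F)F)ccc21` is not yet measured. The change from compound 3 to compound 4 is (dimethylamino)methyl in place of methylsulfanyl on a saturated chain carbon, two bonds along the chain from an aromatic nitrogen.

Going by the values given here, no measured step swaps methylsulfanyl for (dimethylamino)methyl, so the direction is not set by the data. Both measured steps show that moving away from a carbonyl-bearing chain to a heteroatom-bearing alkyl chain lowers the number, and compound 4 keeps such a chain. The expected step is therefore a 2.0-fold higher number from compound 3 to compound 4 (0.30 log units; within the scatter), small and inside the scatter. In this assay compound 4 is expected to give about 2 mg/kg, with a range from 0.5 mg/kg to 8 mg/kg.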

Compound 4, dose for half-maximal effect: 9 mg/kg
Compound 4: middle estimate off by 4.5-fold (0.65 log units), on the low side, and the stated range ends below it.
By their numbers in this assay, from the lowest: compound 3; then compounds 2 and 4 (each within the scatter of the next). At a limit, above all of these: compound 1.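

In this assay the exchange of methylsulfanyl for (dimethylamino)methyl, on a saturated chain carbon two bonds along the chain from an aromatic nitrogen, is not neutral: a 9.0-fold higher number from compound 3 to compound 4 (0.95 log units; beyond the scatter), so a heteroatom-bearing alkyl chain as such does not bring the low number of compound 3. The 3-(dimethylamino)propyl chain is not separated from the carbamoyl chain, with a 1.3-fold higher number from compound 2 to compound 4 (0.11 log units; within the scatter), which leaves the 2-(methylsulfanyl)ethyl chain of compound 3 as the only chain here set apart from both. The comparison with the methoxycarbonylmethyl chain gives only a floor, an at least 1.1-fold lower number from compound 1 to compound 4 (0.04 log units; that floor lies within the scatter), and it cannot be read as a size, as compound 1 stands at a limit of the assay: the limit of > 10 mg/kg in this assay, at which 1 of the 4 values shown sits.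

The change replaces the sulfur with a nitrogen and lengthens the chain at once, and the compounds shown do not separate the two: that would take a 2-(dimethylamino)ethyl chain or a 3-(methylsulfanyl)propyl chain. Also open, from the compounds shown here alone, is how a chain with an ether oxygen in place of the sulfur, or one ending in a carboxylic acid, would read in this assay on the shared core.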